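Pyridyl to thiazolyl swap on the pyrrolidinone: cytotoxicity note

The compounds below may be only part of what the source reports. "The series", "measured", "known", "first", "only" and "open" are said of these compounds alone.

Going by the values given here, compound 1 `O=C1CC(c2ccccn2)CN1c1cnn2c1CN(C(=O)Nc1cc(F)c(F)c(F)c1)C(C1CC1)C2` is the only member of the series with a number in a toxicity assay on HepG2 2.2.15 cells (Homo sapiens) for cytotoxicity, read by CellTiter-Glo; on this read-out lower numbers stand for higher toxicity in this test and higher numbers for lower toxicity in this test; there compound 1 gives 96200 nM. Compound 2 `C[C@H]1Cn2ncc(N3CC(c4ccccc4)CC3=O)c2CN1S(=O)(=O)Nc1cc(F)c(F)c(F)c1` reaches only a limit of this assay, where compound 2 gives > 2000 nM. Beyond that, the limit of > 2000 nM in this assay, at which 1 of the 2 values shown sits, is all the second entry adds. Compound 3 `O=C1CC(c2nccs2)CN1c1cnn2c1CN(C(=O)Nc1cc(F)c(F)c(F)c1)C(C1CC1)C2` differs from compound 1 by 1,3-thiazol-2-yl in place of pyridin-2-yl on a saturated ring carbon. Among the compounds with values here, no measured pair of this kind exists in this assay, so the step is expected to remain within the usual scatter, in either direction or none: a 1.2-fold lower number from compound 1 to compound 3 (0.08 log units; within the scatter). Compound 3 is therefore estimated at 80000 nM, within 30000 nM to 200000 nM.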

Compound 3, half-maximal cytotoxic concentration: 115000 nM
Estimate against measurement, compound 3: 1.4-fold (0.16 log units) below; low and high end bracket the measured number.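

Going by these compounds alone, this is the first readable step at the saturated ring carbon of the pyrrolidinone: 1,3-thiazol-2-yl in place of pyridin-2-yl gives a 1.2-fold higher number from compound 1 to compound 3 (0.08 log units; within the scatter) in this assay, so the two compounds cannot be told apart in this test. At this position, the five-membered aromatic ring with 2 hetero atoms and the six-membered aromatic ring with 1 hetero atom read alike. Nothing measured here accounts for this step.

On these data alone, whether a carboxylic acid or an aminomethyl group on the same carbon would shift the number in this assay remains open. So does whether the result holds on any other core.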